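The compounds below may be only part of what the source reports. "The series", "measured", "known", "first", "only" and "open" are said of these compounds alone.

Measured so far:
- compound 1, `N=c1c2c(-c3ccccc3)c(-c3ccccc3)n(CC3CC3)c2ncn1C1CCOCC1`: 830 nM; 832 nM (2 entries)
- compound 2, `COc1ccc(Cn2c(-c3ccccc3)c(-c3ccccc3)c3c(=N)n(CC4CCOCC4)cnc32)cc1`: 9310 nM; 9330 nM (2 entries)
- compound 3, `Cc1c(C)n(Cc2ccccc2)c2ncn([C@H]3CC[C@H](O)CC3)c(=N)c12`: > 20000 nM

All three compounds share the same core and were tested in a functional assay on PC-3M cells (Homo sapiens) for antiproliferative activity, read by microscopy, with a stated time of 24 h; on this read-out lower numbers stand for stronger inhibition and higher numbers for weaker inhibition. Compound 1 gives 830 nM; 832 nM (2 entries), and compound 2 gives 9310 nM; 9330 nM (2 entries); each was measured twice, as the several entries of compound 1 in this assay, 830 nM; 832 nM (2 entries) and the several entries of compound 2 in this assay, 9310 nM; 9330 nM (2 entries) show. Compound 3 stands apart: in this assay it gives only a limit, > 20000 nM, not a number, as the limit of > 20000 nM in this assay, at which 1 of the 3 values shown sits, records.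

The step to be followed goes from compound 3 to compound 4, `Cc1c(C)n(Cc2ccccc2)c2ncn(CCCO)c(=N)c12`. The change is 3-hydroxypropyl in place of 4-hydroxycyclohexyl on an aromatic nitrogen. Going by the values given here, since compound 3 sits at the limit, there is no number from which a step can be counted, and no measured pair here shows what this exchange does.

With nothing pointing to a gain, compound 4 is expected to stay weak in this assay, at an estimated 25000 nM, most likely between 8000 nM and 80000 nM. The step this estimate implies, a step that the limit leaves unreadable from compound 3 to compound 4, is expected to be none beyond the scatter, with a real chance that only a limit is reported again.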

Compound 4, half-maximal inhibitory concentration: > 20000 nM
Compound 4: only a limit was reported; the forecaster's own chance of this, stated with the estimate: 65%; the middle value is on the limit's open side.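

In this assay compound 4 gives only a limit, > 20000 nM. Compound 3 also gives only a limit, so no step can be read between compound 3 and compound 4. The compounds shown leave open how strongly either inhibits, and so what exchanging 4-hydroxycyclohexyl for 3-hydroxypropyl does.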